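The source may report more compounds than this note shows. Statements on the series, on what has been measured and on what is new or still open speak of the compounds shown alone.

Compound 1 `COc1ccc(C(=O)c2cc(OC)c(OC)c(OC)c2)cc1NC(=O)/C=C/c1cc(OC)c(OC)c(OC)c1`: 1200 nM
Compound 2 `COc1ccc(C(=O)c2cc(OC)c(OC)c(OC)c2)cc1NC(=O)/C=C/c1ccc(C(F)(F)F)cc1`: 100 nM

For the measured compounds named here, in a functional assay on B16 cells (Mus musculus) for cytotoxicity, read by MTT assay, with a stated time of 72 h (a higher number here means a weaker inhibitor, a lower number a stronger inhibitor), compound 2 gives the lowest of the two numbers, with compound 1 its only neighbour. Going by the values given here, the one measured step, a 12-fold lower number from compound 1 to compound 2 (1.08 log units; beyond the scatter), shows that the group carried on the chain-borne ring decides much of the spread. Compound 3 `COc1ccc(C(=O)c2cc(OC)c(OC)c(OC)c2)cc1NC(=O)/C=C/c1ccc(N)cc1` differs from compound 2 by amino in place of trifluoromethyl on an aromatic carbon. Among the compounds with values here, no measured pair shows amino in place of trifluoromethyl, so the direction rests on judgement alone. Compound 3 is expected to move by a 4.0-fold higher number from compound 2 to compound 3 (0.60 log units; beyond the scatter) toward a higher number, with an estimated value of 400 nM and a range from 100 nM to 2000 nM.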

Compound 3, half-maximal inhibitory concentration: 7900 nM
The estimate for compound 3 lay 20-fold (1.30 log units) below the measured number; measured number above the stated range.
By their numbers in this assay, from the lowest: compound 2; then compound 1; then compound 3.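

In this assay, amino in place of trifluoromethyl gives a 79-fold higher number from compound 2 to compound 3 (1.90 log units; beyond the scatter), so a single group on this aromatic carbon, para to a large group, can separate the lowest of the three numbers from the highest. The 4-aminophenyl ring also falls behind the 3,4,5-trimethoxyphenyl ring, with a 6.6-fold higher number from compound 1 to compound 3 (0.82 log units; beyond the scatter), so the two rings that lack trifluoromethyl are not equivalent either. Nothing measured here bears on the reason for these steps. As far as these compounds go, whether a nitrile or a chlorine at this place would stay near compound 2 or move toward compound 3 remains open, as does the effect of an acetylated amine.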